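One More Hydroxy on the Chain of Compound 3

The source may hold more compounds than are shown below. What is called first, only, known or untested is meant among the compounds shown, and "the series" means these compounds.

- compound 1 `C[C@H]1C(=O)N(C)C=Cc2ccccc21`: >= 86 ug/mL (a limit)
- compound 2 `C[C@H]1C(=O)N(C)C=Cc2cc(OC(CO)CO)ccc21`: >= 142 ug/mL (a limit)
- compound 3 `C[C@H]1C(=O)N(C)C=Cc2cc(CCO)ccc21`: >= 108 ug/mL (a limit)

All three results in a physicochemical assay for solubility (on this read-out higher numbers stand for higher solubility and lower numbers for lower solubility), are limits rather than numbers. Compound 3 stands at >= 108 ug/mL, which is a limit. Compound 4 `C[C@H]1C(=O)N(C)C=Cc2cc(C(O)CO)ccc21` differs from compound 3 by hydroxy in place of hydrogen on a saturated chain carbon bound to an aromatic carbon and a saturated chain carbon, so 2-hydroxyethyl becomes 1,2-dihydroxyethyl. Within the data shown here, three measured steps bear on this change: a step that the two limits leave unreadable from compound 1 to compound 3, a step that the two limits leave unreadable from compound 1 to compound 2 and a step that the two limits leave unreadable from compound 2 to compound 3. None has a readable size, so they point in no direction. The expected result is therefore no change beyond the usual scatter, and the estimate is a step that the limit leaves unreadable from compound 3 to compound 4. The expected value for compound 4 is 140 ug/mL, with an estimated range from 100 ug/mL to 260 ug/mL. In this assay this may again be only a limit.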

Compound 4, solubility: >= 101 ug/mL
Compound 4: only a limit was reported; the forecaster's own chance of this, stated with the estimate: 80%; the middle value does not contradict the limit.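

Among these compounds, compound 1, compound 2, compound 3 and compound 4 are all reported only as limits in this assay, and no step among them can be read. As far as these compounds go, whether 1,2-dihydroxyethyl differs from 2-hydroxyethyl in this read-out stays open.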